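The source may hold more compounds than are shown below. What is called first, only, known or untested is meant among the compounds shown, and "the series" means these compounds.

The series rests on one shared core; compound 1 `COc1ccc(N2C(=O)COc3ccc(-c4cnc5ccccc5c4)cc32)cc1`, compound 2 `Cc1ccc(N2C(=O)COc3ccc(-c4cnc5ccccc5c4)cc32)cc1` and compound 3 `O=C1COc2ccc(-c3cnc4ccccc4c3)cc2N1c1ccc(Cl)cc1` differ only in a single substituent. In a functional assay on HepG2 cells (Homo sapiens) for antiproliferative activity, read by MTT assay, with a stated time of 72 h (a lower number here means a stronger inhibitor, a higher number a weaker inhibitor), compound 1 gives > 40000 nM, which is a limit of the assay and not a number. Compound 2 likewise gives > 40000 nM in this assay, again a limit. Compound 3 alone returns a number, 32700 nM in this assay, and so stands as the only measured point of the three. The other two sit at the limit of > 40000 nM in this assay, at which 2 of the 3 values shown sit. Accordingly the steps of an at least 1.2-fold lower number from compound 1 to compound 3 (0.08 log units; that floor lies within the scatter) and an at least 1.2-fold lower number from compound 2 to compound 3 (0.08 log units; that floor lies within the scatter) are floors only, and a step that the two limits leave unreadable from compound 1 to compound 2. Compound 4 `O=C1COc2ccc(-c3cnc4ccccc4c3)cc2N1c1ccc(F)cc1` carries fluoro in place of chloro on an aromatic carbon. For the measured compounds named here, nothing measured so far separates methoxy, methyl and chloro beyond the scatter, so no direction can be read for fluoro; the whole set is weak. Compound 4 is therefore expected to shift little, a 1.2-fold higher number from compound 3 to compound 4 (0.09 log units; within the scatter), with a fair chance of ending at the limit. Compound 4 is estimated at 40000 nM, within 15000 nM to 100000 nM.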

Compound 4, half-maximal inhibitory concentration: 37200 nM
Compound 4: the middle estimate sits 1.1-fold (0.03 log units) above what was measured, within the range that was stated.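

In this assay, for the compounds shown here, the change from 4-chlorophenyl to 4-fluorophenyl gives the only step with a number at both ends, a 1.1-fold higher number from compound 3 to compound 4 (0.06 log units; within the scatter) and so no readable separation between the two halogens at this position, para to a large group. The step of an at least 1.0-fold lower number from compound 2 to compound 4 (0.03 log units; that floor lies within the scatter) and the step of an at least 1.0-fold lower number from compound 1 to compound 4 (0.03 log units; that floor lies within the scatter) are floors only, so fluoro is not separated from methyl or methoxy either. The measured points now number two, yet the set still rests largely on an assay limit: the limit of > 40000 nM in this assay, at which 2 of the 4 values shown sit.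

From the compounds shown here alone, whether an amine, a carboxylic acid or a longer chain at this position would move the value beyond the scatter remains open. So does the effect of any change elsewhere on the shared core, including the amide carbonyl.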